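Cytotoxicity notes: bromo analogue of compound 3

The source may report more compounds than this note shows. Statements on the series, on what has been measured and on what is new or still open speak of the compounds shown alone.

The series comprises compound 1 `CC1(c2ccc(Nc3nc(NCc4ccccc4)nc(NCc4ccccc4)n3)cc2)NC(=O)c2ccccc2N1` and compound 2 `CCCCCNc1nc(NCCCCC)nc(Nc2ccc(C3(C)NC(=O)c4ccccc4N3)cc2)n1`, both measured in an ADME assay on J774.A1 cells (Mus musculus) for cytotoxicity, read by MTT assay, with a stated time of 72 h (on this read-out higher numbers stand for lower toxicity in this test and lower numbers for higher toxicity in this test), together with compound 3 `Nc1nc(-c2ccccc2)cc(-c2ccc(C3NC(=O)c4ccccc4N3)cc2)n1` and the unmeasured compound 4 `Nc1nc(-c2ccc(Br)cc2)cc(-c2ccc(C3NC(=O)c4ccccc4N3)cc2)n1`. Compound 1 gives > 400000 nM, which is a limit of this assay and not a number. Compound 2 likewise gives > 400000 nM, again a limit of this assay. Compound 3 has no result in this assay; its entry reads "not determined" (no result reported), so no number places it among the others, and the only reference point is the limit of > 400000 nM in this assay, at which 2 of the 3 values shown sit. The change from compound 3 to compound 4 is bromo in place of hydrogen on an aromatic carbon. For the measured compounds named here, no step between measured compounds is known, so no shift beyond the scatter is expected from this change in this assay. Compound 4 is expected to give 300000 nM, within 60000 nM to 800000 nM.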

Compound 4, half-maximal cytotoxic concentration: 125000 nM
Compound 4: the middle estimate sits 2.4-fold (0.38 log units) above what was measured; low and high end bracket the measured number.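

No step can be read from compound 3 to compound 4, and nothing at hand bears on the result for compound 4. In this assay the compounds shown leave open what bromo in place of hydrogen does to the read-out.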